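A few compounds are considered here, and "the series" means these few. Any claim that something is new, unique, unknown or untested is made for them only; others in the source may bear on it.

Compound 1 `COc1ccc(Nc2nc(-c3cccc(F)c3)nc3ccc(F)cc23)cc1` gives 48400 nM in a functional assay on MCF7 cells (Homo sapiens) for cytotoxicity, read by MTT assay, with a stated time of 48 h; on this read-out higher numbers stand for weaker inhibition and lower numbers for stronger inhibition. Compound 2 `COc1ccccc1Nc1nc(-c2cccc(F)c2)nc2ccc(F)cc12` reaches only a limit of this assay, > 50000 nM. Compound 3 `Fc1cccc(Nc2nc(-c3cccc(F)c3)nc3ccc(F)cc23)c1` gives 48700 nM.

Compound 1 and compound 3 thus sit within the scatter of each other, as a 1.0-fold higher number from compound 1 to compound 3 (0.00 log units; within the scatter) shows, and compound 2 stands at a limit (the limit of > 50000 nM in this assay, at which 1 of the 3 values shown sits), so no ordering among the three can be drawn. Compound 4 `Fc1cccc(-c2nc(Nc3ccc(Cl)cc3)c3cc(F)ccc3n2)c1` differs from compound 1 in one place: chloro in place of methoxy on an aromatic carbon. The steps measured so far all exchange the aryl group on the nitrogen of the shared core, and none moved the read-out: an at least 1.0-fold higher number from compound 1 to compound 2 (0.01 log units; that floor lies within the scatter), a 1.0-fold higher number from compound 1 to compound 3 (0.00 log units; within the scatter) and an at least 1.0-fold lower number from compound 2 to compound 3 (0.01 log units; that floor lies within the scatter) all lie within the scatter. By that analogy the exchange of a 4-methoxyphenyl for a 4-chlorophenyl is expected to leave the read-out where compound 1 stands. The expected step in this assay is a 1.0-fold lower number from compound 1 to compound 4 (0.00 log units; within the scatter), within the scatter. For compound 4 the estimate is 48000 nM, with a range from 24000 nM to 100000 nM, and a fair chance that only a limit is reported.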

Compound 4, half-maximal inhibitory concentration: > 50000 nM
Compound 4 gave a limit, no number; the forecaster's own chance of this, stated with the estimate: 35%; at least 1.0-fold (0.01 log units) between middle value and limit.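

Chloro in place of methoxy on an aromatic carbon, para to a large group, changes the substituent while leaving its place unchanged, and this exchange shows no movement beyond the scatter: an at least 1.0-fold higher number from compound 1 to compound 4 (0.01 log units; that floor lies within the scatter). The exchange of 3-fluorophenyl for 4-chlorophenyl on the nitrogen reads the same way, an at least 1.0-fold higher number from compound 3 to compound 4 (0.01 log units; that floor lies within the scatter), and both figures are only floors, so the real distance of compound 4 from compound 1 and compound 3 cannot be told. Compound 2 and compound 4 both stand at a limit, and the step between them cannot be read: the limit of > 50000 nM in this assay, at which 2 of the 4 values shown sit.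

Open, as far as these compounds go, is whether an amine or a carboxylic acid at this same place would give a clear number in this assay. Also open, from the compounds shown here alone, is whether a change elsewhere on the shared core would move the read-out beyond the scatter.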